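A Single Inverted Stereocentre Under Test

This account rests on a few compounds, and the source may have more. Where it says the series, first, only, none or still open, it means among the compounds named here.

Among the compounds with values here, in an ADME assay on the whole organism (strain Wistar) for pharmacokinetics, with Rattus norvegicus as the target, given by the intravenous route (a higher number here means faster removal of the compound, a lower number slower removal), compound 2 (`CC[C@H](c1ccc(C(=O)O)c(Oc2cccc(Cl)c2)c1OC)N1CCC[C@H](n2cc(C)c(=O)[nH]c2=O)C1`) gives 84 mL/min/kg, the only number available. Compound 1 (`CC[C@@H](c1ccc(C(=O)O)c(Oc2cccc(Cl)c2)c1F)N1CCC[C@H](n2cc(C)c(=O)[nH]c2=O)C1`) is recorded as "not determined" (no result reported). Compound 3 (`CCC[C@H](c1ccc(C(=O)O)c(Oc2cccc(Cl)c2)c1OC)N1CCC[C@H](n2cc(C)c(=O)[nH]c2=O)C1`) is recorded as "not determined" (no result reported). Neither entry offers any comparison, and compound 4 (`CC[C@@H](c1ccc(C(=O)O)c(Oc2cccc(Cl)c2)c1OC)N1CCC[C@H](n2cc(C)c(=O)[nH]c2=O)C1`) has yet to be measured. Compound 4 differs from compound 2 only in configuration as drawn (the two compounds have the same atoms and bonds and differ only in configuration as drawn: 1 of 2 stereo elements differ; a stereocentre at a saturated chain carbon is drawn R in compound 2 and S in compound 4): a stereocentre at a saturated chain carbon is drawn R in compound 2 and S in compound 4. Within the data shown here, no measured step shows what such an inversion does, so no shift beyond the scatter in this assay is expected, in either direction. The expected change is small, a 1.1-fold lower number from compound 2 to compound 4 (0.05 log units; within the scatter). For compound 4 the estimated clearance is 75 mL/min/kg, with an expected range of 40 mL/min/kg to 140 mL/min/kg.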

Compound 4, clearance: 73 mL/min/kg
Compound 4: middle estimate off by 1.0-fold (0.01 log units), on the high side, within the range that was stated.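

Inverting the stereocentre at the saturated chain carbon gives, in this assay, a 1.2-fold lower number from compound 2 to compound 4 (0.06 log units; within the scatter). Within the data shown here, until now no pair offered any step at this position, and this one shows that clearance does not distinguish the two drawn configurations when the rest of the structure stays the same. The reading rests on one thing: the fact that compounds 2 and 4 differ only in the configuration as drawn.

Still open, as far as these compounds go, is whether a cyclopropyl group on this carbon, in place of the ethyl chain, would move clearance beyond the scatter. Also open, from the compounds shown here alone, is what a tetrazole in place of the carboxylic acid would do in this assay.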